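Moving a Trifluoromethyl Group Across a Shared Core

This account rests on a few compounds, and the source may have more. Where it says the series, first, only, none or still open, it means among the compounds named here.

Three compounds have been measured in a functional assay on HeLa cells (Homo sapiens) for inhibition; a higher number here means a weaker inhibitor, a lower number a stronger inhibitor:
compound 1, `Oc1cccc(-c2cc(-c3cccc(C(F)(F)F)c3)cc(-c3ccccc3O)n2)c1`, gives 19500 nM.
compound 3, `Oc1cccc(-c2cc(-c3cccc(C(F)(F)F)c3)cc(-c3cccc(O)c3)n2)c1`, gives 12700 nM.
compound 2, `Oc1cccc(-c2cc(-c3ccc(C(F)(F)F)cc3)cc(-c3ccccc3O)n2)c1`, gives only a limit of the assay, > 50000 nM.

Compound 1 and compound 3 share one core and differ in a single group: 3-hydroxyphenyl in place of 2-hydroxyphenyl on an aromatic carbon. This change gave a 1.5-fold lower number from compound 1 to compound 3 (0.19 log units; within the scatter), so the two values cannot be told apart. Compound 2 differs from compound 1 in another way: 4-(trifluoromethyl)phenyl in place of 3-(trifluoromethyl)phenyl on an aromatic carbon. Here the change gave an at least 2.5-fold higher number from compound 1 to compound 2 (0.40 log units; beyond the scatter), and since the value of compound 2 is a limit, (the limit of > 50000 nM in this assay, at which 1 of the 3 values shown sits), the true step may well be larger than the number shows.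

Compound 4, `Oc1cccc(-c2cc(-c3ccc(C(F)(F)F)cc3)cc(-c3cccc(O)c3)n2)c1`, has not yet been measured. It differs from compound 3 by 4-(trifluoromethyl)phenyl in place of 3-(trifluoromethyl)phenyl on an aromatic carbon. This is the same kind of change as that from compound 1 to compound 2, though the surroundings are not identical: in compound 4 the entering group sits meta to two 3-hydroxyphenyl groups, whereas in compound 2 it sits meta to a 2-hydroxyphenyl group and meta to a 3-hydroxyphenyl group.

For compound 4 a step of similar size is expected, a 3.1-fold higher number from compound 3 to compound 4 (0.50 log units; beyond the scatter), resting on the measured at least 2.5-fold higher number from compound 1 to compound 2 (0.40 log units; beyond the scatter). Compound 4 is therefore estimated at about 40000 nM, between 20000 nM and 100000 nM, with a real chance that the assay again returns only a limit.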

Compound 4, half-maximal inhibitory concentration: > 50000 nM
Compound 4: only a limit was reported; the forecaster's own chance of this, stated with the estimate: 45%; at least 1.2-fold (0.09 log units) between middle value and limit.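

In this assay compound 4 gives > 50000 nM, which is a limit of the assay and not a number. Putting 4-(trifluoromethyl)phenyl in place of 3-(trifluoromethyl)phenyl on the core of compound 3 gave an at least 3.9-fold higher number from compound 3 to compound 4 (0.59 log units; beyond the scatter), so the loss of inhibition seen on the core of compound 1 appears again, in the same direction, on a second core: the same change on two cores in this assay, an at least 2.5-fold higher number (0.40 log units; beyond the scatter) from compound 1 to compound 2 and an at least 3.9-fold higher number (0.59 log units; beyond the scatter) from compound 3 to compound 4; the limit leaves it open whether they differ This does not show how large either step really is or whether the change costs the same on both cores, and the step from compound 2 to compound 4 cannot be read at all, with a limit on each side.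

Going by these compounds, it remains open whether a chlorine, a methyl or a methoxy group in place of the trifluoromethyl group would show the same drop on these two cores. Also open, on these data alone, is whether an amine or a carboxylic acid in place of the hydroxyl groups would keep the inhibition of compound 1 and compound 3, and how much inhibition, if any, compound 2 and compound 4 truly have.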